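The source may hold more compounds than are shown below. What is called first, only, known or untested is meant among the compounds shown, and "the series" means these compounds.

Three chalcone-type compounds built on a shared core were examined for cytotoxicity. Compound 1 `COc1ccc(-c2cc(/C=C/C(=O)c3ccc(OC)c(OC)c3)[nH]n2)cc1`, compound 2 `COc1ccc(C(=O)/C=C/c2cc(-c3cc(OC)c(OC)c(OC)c3)n[nH]2)cc1` and compound 3 `COc1cc(C(=O)/C=C/c2cc(-c3cc(OC)c(OC)c(OC)c3)n[nH]2)cc(OC)c1OC` differ only in the methoxy pattern of their two aryl ends. In a functional assay on HOP-62 cells (Homo sapiens) for cytotoxicity, read by sulforhodamine B assay, with a stated time of 48 h, tested at 0.01 uM (a lower number here means a stronger effect, a higher number a weaker effect of the compound at the concentration tested), compound 1 gives 97%. In the same assay compound 2 gives 99%. Compound 3 gives 97% in this assay. The three numbers sit within the usual scatter of one another, so compound 2 cannot be set apart from compound 1 or compound 3 on this evidence; all three leave the cells essentially untouched at the concentration tested.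

Compound 4 `COc1cc(-c2cc(/C=C/C(=O)c3ccc(F)c(F)c3)[nH]n2)cc(OC)c1OC` has not yet been measured. It departs from compound 2 in one place: 3,4-difluorophenyl in place of 4-methoxyphenyl on a carbonyl carbon. For the measured compounds named here, no step between two measured compounds is available to size such a change, and every measured compound clusters near the same value. On that basis the change from compound 2 to compound 4 is expected to produce no step beyond the scatter, that is a number 2 percentage points lower from compound 2 to compound 4 (within the scatter). Compound 4 is therefore estimated to give 97% in this assay, with a range from 88% to 104%.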

Compound 4, a percentage reported as activity, at one concentration (the size of the read-out at that concentration, not a potency): 100%
Beside the measured number, compound 4's estimate is 3 percentage points below it; the measured number falls inside the stated range.
By their numbers in this assay, from the lowest: compounds 1, 3, 2 and 4 (each within the scatter of the next).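

In this assay, for the compounds shown here, the exchange of 4-methoxyphenyl for 3,4-difluorophenyl on a carbonyl carbon gives a number 1 percentage points higher from compound 2 to compound 4 (within the scatter) and is the first step that can be read at this place. An aryl end with two fluorines and no hydrogen-bond acceptor thus reads the same as one carrying a methoxy group, so this exchange shows no effect on the cells at the concentration tested. No measurement shown offers an explanation for this result.

Going by these compounds, whether an amine or a carboxylic acid on the aryl end at this carbonyl carbon would move the read-out remains open. Also open, on these data alone, is whether compound 2 and compound 4 would separate at a concentration where the cells respond, since a read-out this flat cannot rank them.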